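A few compounds are considered here, and "the series" means these few. Any claim that something is new, unique, unknown or untested is made for them only; others in the source may bear on it.

Of the compounds shown here, two built on a shared core have been read in a functional assay on PANC-1 cells (Homo sapiens) for cytotoxicity, read by MTT assay, with a stated time of 72 h; a higher number here means a weaker inhibitor, a lower number a stronger inhibitor. In this assay, compound 1 `COc1cccc(NC2=CC(=O)c3ncncc3C2=O)c1` gives 600 nM and compound 2 `O=C1C(Nc2cccc(B(O)O)c2)=CC(=O)c2ncncc21` gives 9000 nM, the higher of the two numbers and so the weaker inhibitor of the pair. Compound 3 `CC(=O)c1cccc(NC2=CC(=O)c3ncncc3C2=O)c1` departs from compound 2 in a single place: a group of 3 heavy atoms (2 carbon, 1 oxygen; no ring) in place of a group of 3 heavy atoms (1 boron, 2 oxygen; no ring), on an aromatic carbon. The acetyl group thus stands in place of a group of 3 heavy atoms (1 boron, 2 oxygen; no ring), on an aromatic carbon. For the measured compounds named here, only one measured step bears on this exchange, a 15-fold higher number from compound 1 to compound 2 (1.18 log units; beyond the scatter), a large one, beyond the scatter, made at the same place on the ring. Acetyl itself has not been measured, so that step guides the size of the change without fixing it. The same group of compound 2 leaves again here, and most, though not all, of that gap is expected to close in this assay. The expected change is a 7.5-fold lower number from compound 2 to compound 3 (0.88 log units; beyond the scatter), toward a stronger inhibitor. For compound 3 the estimated value is 1200 nM, with an expected range from 350 nM to 4500 nM.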

Compound 3, half-maximal inhibitory concentration: 900 nM
Estimate against measurement, compound 3: 1.3-fold (0.12 log units) above; the measured number falls inside the stated range.
By their numbers in this assay, from the lowest: compounds 1 and 3 (each within the scatter of the next); then compound 2.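

In this assay, putting acetyl in place of the group of boron and two oxygens gives a 10-fold lower number from compound 2 to compound 3 (1.00 log units; beyond the scatter), so the weak reading of compound 2 does not extend to every group on this aromatic carbon. Acetyl in place of methoxy gives a 1.5-fold higher number from compound 1 to compound 3 (0.18 log units; within the scatter), which means that this assay cannot separate these two groups at this place, even though they differ in size and atom make-up. For the compounds shown here, of the three groups, only the one in compound 2 stands apart, and nothing measured here accounts for that difference.

From the compounds shown here alone, it remains open whether an amine, a carboxylic acid or a nitrile on this aromatic carbon would read with compound 1 and compound 3, with compound 2, or stronger than all of them. Going by these compounds, all three compounds change at this one place and are read only in this assay, so how the same exchanges would behave elsewhere on the shared core, or in any other assay, also remains unknown.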